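This account rests on a few compounds, and the source may have more. Where it says the series, first, only, none or still open, it means among the compounds named here.

Among the measured compounds shown here, compound 2, with the structure `O=C(O)CC(c1ccc(OCC2COc3ccc(Cl)cc3O2)cc1)c1cnco1`, sits at the higher of the two numbers measured so far. In a functional assay on HEK293 cells for agonist activity at Free fatty acid receptor 1 (Homo sapiens), read by fluorescence and calcium flux, with a stated time of 10 min (a higher number here means that more compound is needed for the effect, a lower number that less compound is needed), compound 2 gives 1030 nM. For the measured compounds named here, its only measured neighbour is compound 1, `CCOC(CC(=O)O)c1ccc(OCC2COc3ccc(Cl)cc3O2)cc1`, which in this assay gives 640 nM; the two are separated by a 1.6-fold higher number from compound 1 to compound 2 (0.21 log units; within the scatter), so the two numbers are not distinguishable on this evidence.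

Compound 3, `Cn1ccnc1C(CC(=O)O)c1ccc(OCC2COc3ccc(Cl)cc3O2)cc1`, has not been measured. It differs from compound 2 in one place: 1-methyl-1H-imidazol-2-yl in place of 1,3-oxazol-5-yl on a saturated chain carbon bound to an aromatic carbon and a saturated chain carbon. Both groups are five-membered aromatic rings with two hetero atoms and two hydrogen-bond acceptors, so the exchange is between two similar ring groups on the same chain carbon.

Going by the values given here, the one step that bears on this position, the step from compound 1 to compound 2, exchanged an ethoxy group for the oxazolyl ring and moved the number only within the scatter. A second exchange of one small aromatic ring for another at the same carbon is therefore expected to leave this assay much where it is, as an estimated 1.0-fold lower number from compound 2 to compound 3 (0.01 log units; within the scatter), with no direction claimed beyond the scatter. Compound 3 is thus expected to give about 1000 nM, within a range from 400 nM to 2500 nM.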

Compound 3, half-maximal effective concentration: 5880 nM
Beside the measured number, compound 3's estimate is 5.9-fold (0.77 log units) below it, outside the stated range (above it).
By their numbers in this assay, from the lowest: compounds 1 and 2 (each within the scatter of the next); then compound 3.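

In this assay this chain carbon proves sensitive to which ring it carries: the exchange gives a 5.7-fold higher number from compound 2 to compound 3 (0.76 log units; beyond the scatter), even though the two groups match in their counts of hetero atoms, hydrogen-bond donors and hydrogen-bond acceptors. The earlier step suggested that the position might accept quite different groups, but the 1-methyl-1H-imidazol-2-yl group stands apart from ethoxy as well, with a 9.2-fold higher number from compound 1 to compound 3 (0.96 log units; beyond the scatter), so the freedom seen between ethoxy and 1,3-oxazol-5-yl does not extend to every five-membered aromatic ring. No measurement offered here accounts for the difference between the two rings.

The change from compound 2 to compound 3 alters the ring atoms, the point of attachment and the added methyl all at once, so these compounds cannot say which of them matters; an unsubstituted 1H-imidazol-2-yl group at the same carbon would separate the methyl from the ring. A plain phenyl ring or a small amine at this carbon would also show whether the higher number belongs to this one ring or to a wider range of groups.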